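Dichlorobenzyl isomers: from compound 3 to compound 4

A few compounds are considered here, and "the series" means these few. Any claim that something is new, unique, unknown or untested is made for them only; others in the source may bear on it.

In a functional assay on MKN-74 cells (Homo sapiens) for antiproliferative activity, with a stated time of 24 h (a lower number here means a stronger inhibitor, a higher number a weaker inhibitor), compound 1 `NC(=O)c1c(NC(=O)c2ccccc2Cl)sc2c1CCN(Cc1ccccc1)C2` gives 14500 nM, compound 2 `NC(=O)c1c(NC(=O)c2ccccc2Cl)sc2c1CCN(Cc1c(Cl)cccc1Cl)C2` gives 4740 nM and compound 3 `NC(=O)c1c(NC(=O)c2ccccc2Cl)sc2c1CCN(Cc1ccc(Cl)cc1Cl)C2` gives 16300 nM. Compound 3 shares the upper end of these numbers: a 1.1-fold higher number from compound 1 to compound 3 (0.05 log units; within the scatter) lies within the scatter, whereas a 3.4-fold higher number from compound 2 to compound 3 (0.54 log units; beyond the scatter) lies beyond it.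

Compound 4 `NC(=O)c1c(NC(=O)c2ccccc2Cl)sc2c1CCN(Cc1cc(Cl)cc(Cl)c1)C2` carries 3,5-dichlorophenyl in place of 2,4-dichlorophenyl on a saturated chain carbon bound to an amine nitrogen in a ring. The only lowering beyond the scatter, a 3.1-fold lower number from compound 1 to compound 2 (0.49 log units; beyond the scatter), belongs to 2,6-dichlorophenyl, a group compound 4 lacks. The other dichlorophenyl group gave a 1.1-fold higher number from compound 1 to compound 3 (0.05 log units; within the scatter), so the closer guide is a step of no real size. The expected change in this assay is a 1.4-fold lower number from compound 3 to compound 4 (0.13 log units; within the scatter), which is no step beyond the scatter. For compound 4 the estimated value is 12000 nM, with an expected range of 5000 nM to 30000 nM.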

Compound 4, half-maximal inhibitory concentration: 23700 nM
Estimate against measurement, compound 4: 2.0-fold (0.30 log units) below; the range from low to high includes it.
By their numbers in this assay, from the lowest: compound 2; then compounds 1, 3 and 4 (each within the scatter of the next).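

In this assay, 3,5-dichlorophenyl in place of 2,4-dichlorophenyl gives a 1.5-fold higher number from compound 3 to compound 4 (0.16 log units; within the scatter), and in place of phenyl it gives a 1.6-fold higher number from compound 1 to compound 4 (0.21 log units; within the scatter), so compound 1, compound 3 and compound 4 cannot be ordered. Compound 2 alone stands apart, with a 5.0-fold higher number from compound 2 to compound 4 (0.70 log units; beyond the scatter), so among the dichlorophenyl isomers shown only 2,6-dichlorophenyl separates from phenyl. No supporting data bear on this result.

Open, as far as these compounds go, is whether a difluorophenyl or dimethylphenyl group at this position would match 2,6-dichlorophenyl. Also open, from the compounds shown here alone, is what a longer chain between the amine nitrogen and the aromatic ring would do.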